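Para Substituent Swaps on a Shared Core: Cyano Next

The source may report more compounds than this note shows. Statements on the series, on what has been measured and on what is new or still open speak of the compounds shown alone.

Measured so far:
compound 1, `Cc1ccc(-n2nc(-c3ccc(C(F)(F)F)cc3O)nc2-c2ccccc2O)cc1`, 71.5%
compound 2, `Oc1cc(C(F)(F)F)ccc1-c1nc(-c2ccccc2O)n(-c2ccc(F)cc2)n1`, 67.2%
compound 3, `Oc1cc(C(F)(F)F)ccc1-c1nc(-c2ccccc2O)n(-c2ccc(I)cc2)n1`, 70.1%

In a functional assay on PC-12 cells (Rattus norvegicus) for cytotoxicity, read by MTT assay, with stated times of 2 h and 24 h, tested at 1 uM (a higher number here means a stronger effect of the compound at the concentration tested, a lower number a weaker effect), compound 3 stands second highest of the three numbers; its nearest neighbour is compound 1 and its furthest compound 2, and both gaps lie within the scatter. Compound 4, `N#Cc1ccc(-n2nc(-c3ccc(C(F)(F)F)cc3O)nc2-c2ccccc2O)cc1`, differs from compound 3 by cyano in place of iodo on an aromatic carbon. Among the compounds with values here, no measured step involves cyano, but the three swaps at the same position, a number 4.3 percentage points lower from compound 1 to compound 2 (within the scatter), a number 1.4 percentage points lower from compound 1 to compound 3 (within the scatter) and a number 2.9 percentage points higher from compound 2 to compound 3 (within the scatter), all stayed within the scatter. The step of a number 1.1 percentage points lower from compound 3 to compound 4 (within the scatter) is therefore expected to stay within the scatter as well. Compound 4 is estimated at 69%, with a range from 58% to 80%.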

Compound 4, a percentage reported as activity, at one concentration (the size of the read-out at that concentration, not a potency): 66.6%
The estimate for compound 4 lay 2.4 percentage points above the measured number; measured number inside the range.
By their numbers in this assay, from the lowest: compounds 4, 2, 3 and 1 (each within the scatter of the next).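

Cyano, which unlike iodo counts a hydrogen-bond acceptor and a triple bond, still leaves this assay unable to separate it from the three earlier groups at this position: a number 3.5 percentage points lower from compound 3 to compound 4 (within the scatter), a number 0.6 percentage points lower from compound 2 to compound 4 (within the scatter) and a number 4.9 percentage points lower from compound 1 to compound 4 (within the scatter). All four para groups on the shared core now fall within the scatter of one another. No evidence on the cause of this flat picture is available. From the compounds shown here alone, whether an amine or a carboxylic acid at this position would move the number beyond the scatter stays open.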